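Swapping the halogenated benzyl arm on a shared thioether scaffold

The source may hold more compounds than are shown below. What is called first, only, known or untested is meant among the compounds shown, and "the series" means these compounds.

Measured so far:
- compound 1, `COc1nc(N[C@H](CCC(=O)O)C(=O)O)nc(OC)n1`: 0.34%
- compound 2, `O=c1nc(SCc2ccccc2)nc(SCc2ccccc2F)[nH]1`: "not determined" (no result reported)
- compound 3, `O=c1nc(SCc2ccccc2)nc(SCc2ccccc2[N+](=O)[O-])[nH]1`: "not determined" (no result reported)

In an assay for inhibition of Pro-cathepsin H (Homo sapiens), read by fluorescence, tested at 50 uM (on this read-out higher numbers stand for more inhibition at the one concentration tested (going by the name of the read-out) and lower numbers for less inhibition), compound 1 gives 0.34%, a reading that amounts to essentially no inhibition at the single concentration tested. Compound 2 stands on no number at all in this assay: its entry reads "not determined" (no result reported). The same is true of compound 3, whose entry reads "not determined" (no result reported), so nothing can be said about where either of them lies relative to compound 1.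

The step followed here leads from compound 2 to compound 4, `O=c1nc(SCc2ccccc2)nc(SCc2ccc(Cl)cc2)[nH]1`. The two differ in one place only: 4-chlorophenyl in place of 2-fluorophenyl on a saturated chain carbon bound to a sulfur. Both compounds keep the same core and the same unsubstituted benzyl thioether on the other side; only the halogenated arm is exchanged.

For the measured compounds named here, no measured pair in this set shares this change, and compound 2 itself has no value, so there is no anchor for the size or direction of the step. Going by the values given here, the only number in hand, from compound 1, sits near the floor. Without any step to lean on, a small reading is expected for compound 4, 10%, with a range from 0% to 40%.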

Compound 4, a percentage reported as inhibition, at one concentration (the size of the read-out at that concentration, not a potency): 6.91%
The estimate for compound 4 lay 3.1 percentage points above the measured number; low and high end bracket the measured number.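

In this assay compound 4 gives 6.91%, but compound 2 has no number to set against it, so no step can be read between the two. From the compounds shown here alone, whether 4-chlorophenyl in place of 2-fluorophenyl raises, lowers or leaves unchanged the inhibition stays open. No supporting evidence bears on the reading for compound 4.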